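A few compounds are considered here, and "the series" means these few. Any claim that something is new, unique, unknown or untested is made for them only; others in the source may bear on it.

Measured compounds on record:

Compound 1, `C[C@@H]1CN(c2cccc3c2C[C@H](CN(C)[C@H]2CCCc4cccnc42)NC3)C[C@H](C)N1`: 61 nM
Compound 2, `CN(C[C@@H]1Cc2c(cccc2N2CCNCC2)CN1)[C@H]1CCCc2cccnc21`: 313 nM
Compound 3, `Cc1cnc2c(c1)CCC[C@@H]2N(C)C[C@H]1Cc2c(cccc2N2CCNCC2)CN1`: 16.1 nM

In a functional assay on CCRF-CEM cells for antagonist activity at C-X-C chemokine receptor type 4 (Homo sapiens), read by calcium flux, with stated times of 25 min and 90 s (on this read-out higher numbers stand for weaker inhibition and lower numbers for stronger inhibition), compound 3 gives 16.1 nM, the lowest of the three numbers. Compound 1 gives 61 nM, a gap beyond the scatter, and compound 2 gives 313 nM, the widest gap in the set. Compound 3 thus stands as the most potent of the measured compounds in this assay.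

Compound 4, `CN(C[C@H]1Cc2c(cccc2N2CCNCC2)CN1)[C@H]1CCCc2cccnc21`, has not yet been measured. It is derived from compound 3 by a single change: hydrogen in place of methyl on an aromatic carbon. Among the compounds with values here, no step between measured compounds isolates this change, so no measured pair shows what loss of a methyl at this place does here; compound 2 differs from compound 4 at a stereocentre as well and cannot serve as a reference for the methyl alone.

The working expectation is a small loss of potency for compound 4 relative to compound 3, with the step from compound 3 to compound 4 estimated as a 1.9-fold higher number from compound 3 to compound 4 (0.27 log units; within the scatter), close to the usual scatter. Compound 4 is estimated at 30 nM in this assay, with a range from 12 nM to 80 nM.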

Compound 4, half-maximal inhibitory concentration: 6.08 nM
Beside the measured number, compound 4's estimate is 4.9-fold (0.69 log units) above it, outside the stated range (below it).
By their numbers in this assay, from the lowest: compound 4; then compound 3; then compound 1; then compound 2.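

In this assay, the aromatic carbon two atoms from the ring nitrogen does not need its methyl: hydrogen in place of methyl gives a 2.6-fold lower number from compound 3 to compound 4 (0.42 log units; beyond the scatter), a gain rather than a loss, and the pyridine-bearing end of the series tolerates the bare ring carbon. On the other aromatic ring, piperazin-1-yl in place of 3,5-dimethylpiperazin-1-yl gives a 10-fold lower number from compound 1 to compound 4 (1.00 log units; beyond the scatter), so the unsubstituted piperazine also stands ahead of the dimethylated one in this pair. The largest step belongs to the stereocentre at the saturated ring carbon, drawn S in compound 2 and R in compound 4, with a 51-fold lower number from compound 2 to compound 4 (1.71 log units; beyond the scatter), and that step can be assigned to configuration alone: the fact that compounds 2 and 4 differ only in the configuration as drawn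

From the compounds shown here alone, only hydrogen and methyl appear on the aromatic carbon in these compounds, so the effect of a chlorine atom, a methoxy group or an ethyl group there remains open. Also open, going by these compounds, are whether the methyl step holds with the stereocentre drawn S, and whether a single methyl on the piperazine follows the 3,5-dimethyl pattern.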